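The source may report more compounds than this note shows. Statements on the series, on what has been measured and on what is new or still open speak of the compounds shown alone.

Measured so far in an ADME assay on HepG2 cells (Homo sapiens) for cytotoxicity, read by luminescence, with a stated time of 72 h; on this read-out lower numbers stand for an effect already at smaller amounts and higher numbers for an effect only at larger amounts of compound:

- compound 1 `CCOC(=O)c1c(-c2cccc(OC)c2)[nH]c2cc(OC)ccc2c1=O` gives > 21500 nM (a limit)
- compound 2 `CCOC(=O)c1c(-c2cccc(-c3ccccc3)c2)[nH]c2cc(OC(C)C)ccc2c1=O` gives > 21500 nM (a limit)
- compound 3 `CCOC(=O)c1c(-c2cccc(OC)c2)[nH]c2cc(OC(C)C)ccc2c1=O` gives > 21500 nM (a limit)

For compound 3 the entry > 21500 nM is a limit of the assay and not a number. Going by the values given here, the series so far stands at the limit of > 21500 nM in this assay, at which 3 of the 3 values shown sit, so compound 3 has no numerical rank among the three.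

The next step leads to compound 4 `CCOC(=O)c1c(-c2cccc(OC)c2)[nH]c2cc(OC(F)(F)F)ccc2c1=O`, with trifluoromethyl in place of isopropyl on an oxygen on an aromatic ring. The counted difference is trifluoromethyl in place of isopropyl on an oxygen on an aromatic ring.

Among the compounds with values here, two measured steps bear on this. The nearer one changes the group on the same oxygen, isopropyl in place of methyl, and it is a step that the two limits leave unreadable from compound 1 to compound 3. The other, methoxy in place of phenyl on an aromatic carbon, is a step that the two limits leave unreadable from compound 2 to compound 3. Neither gives a size, and both end at compound 3 with the same limit as their starting compounds.

No step beyond the scatter is therefore expected in this assay, and no direction is expected either, with a further limit the most likely report. The estimated step is a step that the limit leaves unreadable from compound 3 to compound 4. For compound 4 the estimated value is 22000 nM, with an expected range from 10000 nM to 45000 nM.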

Compound 4, half-maximal effective concentration: > 21500 nM
Compound 4: only a limit was reported; the forecaster's own chance of this, stated with the estimate: 80%; the middle value is on the limit's open side.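

In this assay compound 4 gives > 21500 nM, which is a limit and not a number. The steps to compound 4 from compound 3 and from compound 1 cannot be read, and the series stays at one limit: the limit of > 21500 nM in this assay, at which 4 of the 4 values shown sit.

The compounds shown hold no numerical value and leave open whether any of these group changes alters this read-out.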